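The source may report more compounds than this note shows. Statements on the series, on what has been measured and on what is new or still open speak of the compounds shown alone.

Three compounds of the series share one core and differ only at the carbonyl carbon. In a functional assay for inhibition of nuclear factor NF-kappa-B complex (Homo sapiens) (on this read-out lower numbers stand for stronger inhibition and higher numbers for weaker inhibition), compound 1 `COc1ccc2c(c1)OC(c1cc(OC)c(OC)c(OC)c1)C(C(=O)OC(C)(C)C)=C2` gives 14100 nM, compound 3 `COc1ccc2c(c1)OC(c1cc(OC)c(OC)c(OC)c1)C(C(=O)N(C)OC)=C2` gives 11700 nM, and compound 2 `CCCCNC(=O)C1=Cc2ccc(OC)cc2OC1c1cc(OC)c(OC)c(OC)c1` gives 25500 nM, the highest of the three numbers. The measured steps at this position are a 1.8-fold higher number from compound 1 to compound 2 (0.26 log units; within the scatter), a 2.2-fold lower number from compound 2 to compound 3 (0.34 log units; beyond the scatter) and a 1.2-fold lower number from compound 1 to compound 3 (0.08 log units; within the scatter). Compound 4 `COc1ccc2c(c1)OC(c1cc(OC)c(OC)c(OC)c1)C(C(=O)NC(C)(C)C)=C2` differs from compound 2 by tert-butyl in place of butyl on an amide-type nitrogen. For the measured compounds named here, no measured step exchanges one alkyl for another on the amide-type nitrogen, and the steps seen at the carbonyl carbon are small, so no step beyond the scatter is expected in this assay. The expected step is a 1.3-fold lower number from compound 2 to compound 4 (0.11 log units; within the scatter). Compound 4 is estimated at 20000 nM, with a range from 9000 nM to 45000 nM.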

Compound 4, half-maximal inhibitory concentration: 28400 nM
Compound 4: middle estimate off by 1.4-fold (0.15 log units), on the low side, within the range that was stated.
By their numbers in this assay, from the lowest: compounds 3, 1, 2 and 4 (each within the scatter of the next, the first and the last beyond it).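

For the compounds shown here, with a 1.1-fold higher number from compound 2 to compound 4 (0.05 log units; within the scatter) in this assay, the first alkyl-for-alkyl exchange on the amide-type nitrogen, tert-butyl for butyl, stays within the scatter. The (tert-butyl)amino group also stays within the scatter of tert-butoxy, with a 2.0-fold higher number from compound 1 to compound 4 (0.30 log units; within the scatter), whereas replacing methoxy(methyl)amino with it gives a modest step, a 2.4-fold higher number from compound 3 to compound 4 (0.39 log units; beyond the scatter), so compound 2 and compound 4 both stand beyond the scatter of compound 3. No available evidence bears on these differences.

As far as these compounds go, whether a longer chain or a cyclohexyl group on the amide-type nitrogen would give a step beyond the scatter remains open. So does the effect of a carboxylic acid in place of tert-butoxy on the carbonyl carbon.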